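The source may hold more compounds than are shown below. What is called first, only, known or untested is meant among the compounds shown, and "the series" means these compounds.

Compound 1 `COc1ccc2cc([C@H](C)c3nnc(SCc4ccc(F)cc4)n3-c3ccc(Cl)cc3)ccc2c1`: 33600 nM
Compound 2 `COc1ccc2cc([C@H](C)c3nnc(SCc4ccc(F)cc4)n3-c3ccc(F)cc3)ccc2c1`: 60200 nM
Compound 3 `COc1ccc2cc([C@H](C)c3nnc(SCc4c(C)cc(C)cc4C)n3-c3ccc(F)cc3)ccc2c1`: 10200 nM

These three compounds were measured in a functional assay on DU-145 cells (Homo sapiens) for cytotoxicity, read by MTT assay; on this read-out higher numbers stand for weaker inhibition and lower numbers for stronger inhibition. Compound 1 lies within the scatter of compound 2, as the step of a 1.8-fold higher number from compound 1 to compound 2 (0.25 log units; within the scatter) shows. Its number is higher than that of compound 3, which has the lowest number of the three.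

Compound 4 `COc1ccc2cc([C@H](C)c3nnc(SCc4c(Cl)cccc4Cl)n3-c3ccc(Cl)cc3)ccc2c1` has not yet been measured. It keeps the core of compound 1 and changes one group: 2,6-dichlorophenyl in place of 4-fluorophenyl on a saturated chain carbon bound to a sulfur.

Among the measured compounds shown here, two measured steps bear on this change. The closer one is a 5.9-fold lower number from compound 2 to compound 3 (0.77 log units; beyond the scatter). It replaces the same 4-fluorophenyl, at the same place, with 2,4,6-trimethylphenyl. For the measured compounds named here, that group is not 2,6-dichlorophenyl, and no measured compound carries 2,6-dichlorophenyl, so this step can only serve as a loose guide. The other step, a 1.8-fold higher number from compound 1 to compound 2 (0.25 log units; within the scatter), suggests that the fluoro and chloro difference between compound 1 and compound 2 matters little here, so a step seen on compound 2 may reasonably carry over to compound 1.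

A modest move toward a lower number is therefore expected, and the estimated step is a 2.8-fold lower number from compound 1 to compound 4 (0.45 log units; beyond the scatter). For compound 4 the expected value in this assay is 12000 nM, with an estimated range of 4000 nM to 36000 nM.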

Compound 4, half-maximal inhibitory concentration: 36100 nM
Compound 4: the middle estimate sits 3.0-fold (0.48 log units) below what was measured; measured number above the stated range.
By their numbers in this assay, from the lowest: compound 3; then compounds 1, 4 and 2 (each within the scatter of the next).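

In this assay, a 1.1-fold higher number from compound 1 to compound 4 (0.03 log units; within the scatter), so compound 1 and compound 4 cannot be told apart, and 2,6-dichlorophenyl in place of 4-fluorophenyl on a saturated chain carbon bound to a sulfur gives no readable change on this core. Among the compounds shown here, until now the only step at this place was a 5.9-fold lower number from compound 2 to compound 3 (0.77 log units; beyond the scatter), which made it look as though replacing 4-fluorophenyl there might by itself lower the number; the new result shows that this does not hold for every replacement, so what comes in matters, or else the chloro or fluoro group elsewhere on the molecule does. Nothing measured here accounts for the contrast between these two replacements, so it stands as an observation without an explanation.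

On these data alone, it remains open whether 2,4,6-trimethylphenyl would lower the number on the core of compound 1 as it did on that of compound 2, which would separate the effect of the incoming group from that of its background. Also open, as far as these compounds go, is how this place would respond to quite different groups, such as a phenyl ring carrying an amine or a carboxylic acid, or a longer chain in place of the single saturated carbon.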